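A few compounds are considered here, and "the series" means these few. Any claim that something is new, unique, unknown or untested is made for them only; others in the source may bear on it.

Compound 1 `COc1cc(Cn2cc(CNC(=O)c3cn(-c4ccccc4)nc3-c3ccc(Cl)cc3)nn2)cc(OC)c1` was tested in a functional assay on MIA PaCa-2 cells (Homo sapiens) for antiproliferative activity, read by sulforhodamine B assay, with a stated time of 48 h (a higher number here means a weaker inhibitor of growth, a lower number a stronger inhibitor of growth), and compound 1 gives 340 nM. Compound 2 `COc1cc(Cn2cc(CNC(=O)c3cn(-c4ccccc4)nc3-c3ccc(Cl)cc3)nn2)cc(OC)c1OC` carries one added group, (methoxy in place of hydrogen on an aromatic carbon), and in this assay compound 2 gives 3500 nM; the step is a 10-fold higher number from compound 1 to compound 2 (1.01 log units; beyond the scatter). Compound 3 `COc1ccc(-c2nn(-c3ccccc3)cc2C(=O)NCc2cn(Cc3cc(OC)cc(OC)c3)nn2)cc1` differs from compound 1 at one place on the other ring, and in this assay compound 3 gives 5800 nM, so the step is a 17-fold higher number from compound 1 to compound 3 (1.23 log units; beyond the scatter). Compound 4 `COc1ccc(-c2nn(-c3ccccc3)cc2C(=O)NCc2cn(Cc3cc(OC)c(OC)c(OC)c3)nn2)cc1` has not yet been measured. It is made from compound 3 by methoxy in place of hydrogen on an aromatic carbon, the same change that was made from compound 1 to compound 2, at a place described in the same words. The cores of compound 3 and compound 1 differ by methoxy in place of chloro on an aromatic carbon. If the change carries over from the one pair to the other, the step from compound 3 to compound 4 is expected to be a 6.9-fold higher number from compound 3 to compound 4 (0.84 log units; beyond the scatter), resting on a 10-fold higher number from compound 1 to compound 2 (1.01 log units; beyond the scatter). On that basis compound 4 is expected to give about 40000 nM in this assay, most likely between 12000 nM and 120000 nM.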

Compound 4, concentration for 50% growth inhibition: 31600 nM
The estimate for compound 4 lay 1.3-fold (0.10 log units) above the measured number, within the range that was stated.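

Adding the methoxy that turns 3,5-dimethoxyphenyl into 3,4,5-trimethoxyphenyl weakens growth inhibition on the core of compound 3 as it does on the core of compound 1, with a 5.4-fold higher number from compound 3 to compound 4 (0.74 log units; beyond the scatter) in this assay, and the two steps agree: the same change on two cores in this assay, a 10-fold higher number (1.01 log units; beyond the scatter) from compound 1 to compound 2 and a 5.4-fold higher number (0.74 log units; beyond the scatter) from compound 3 to compound 4, 1.9-fold (0.28 log units) apart, within the scatter of two such steps.
Putting methoxy in place of chloro also carries over to the trimethoxyphenyl pair, with a 9.0-fold higher number from compound 2 to compound 4 (0.96 log units; beyond the scatter) and again agreement with the earlier step: the same change on two cores in this assay, a 17-fold higher number (1.23 log units; beyond the scatter) from compound 1 to compound 3 and a 9.0-fold higher number (0.96 log units; beyond the scatter) from compound 2 to compound 4, 1.9-fold (0.28 log units) apart, within the scatter of two such steps.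
Across these four compounds, then, each change has much the same size whichever form the other place takes, but this rests on a single pair of steps for each change in one assay, and it shows neither that the pattern holds on other cores nor why the numbers rise.

Open, going by these compounds, is how a hydroxyl, an amine or an ethoxy group would compare with the added methoxy at the same place. Also open, on these data alone, is how fluoro or a carboxylic acid would compare with chloro and methoxy on the other ring.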